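The compounds below may be only part of what the source reports. "The series", "measured", "known", "first", "only" and "open" are said of these compounds alone.

Measured compounds in an assay on membranes from brain for binding affinity to adenosine receptor A1 (Rattus norvegicus), read by radioligand binding, tested at 20 uM; on this read-out lower numbers stand for less inhibition and higher numbers for more inhibition at the one concentration tested (going by the name of the read-out):
compound 1, `Cn1c(=O)[nH]c2c(cnn2-c2ccccc2[N+](=O)[O-])c1=N`, gives 5%
compound 2, `Cn1c(=O)[nH]c2c(cnn2-c2ccc(N)cc2)c1=N`, gives 0%
compound 3, `Cn1c(=O)[nH]c2c(cnn2-c2ccccc2N)c1=N`, gives 0%

All three numbers lie within the usual scatter of one another. From compound 3 to compound 1 the change is nitro in place of amino on an aromatic carbon; the step it made, a number 5 percentage points higher from compound 3 to compound 1 (within the scatter), is within the scatter. How the cores of compound 2 and compound 3 differ is not broken down here; compound 2 and compound 3 give the same number at the digits printed.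

Compound 4, `Cn1c(=O)[nH]c2c(cnn2-c2ccc([N+](=O)[O-])cc2)c1=N`, is not yet measured. From compound 2 to compound 4 the change is nitro in place of amino on an aromatic carbon. It is the same kind of change as from compound 3 to compound 1, but the place differs: para to a large group here, ortho to a large group there. Because the step of a number 5 percentage points higher from compound 3 to compound 1 (within the scatter) stayed within the scatter, a step of similar size, a number 4 percentage points higher from compound 2 to compound 4 (within the scatter), is expected from compound 2 to compound 4 in this assay. Compound 4 is estimated at 4%, expected between 0% and 15%.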

Compound 4, a percentage reported as inhibition, at one concentration (the size of the read-out at that concentration, not a potency): 5%
For compound 4 the middle estimate is 1 percentage points below the measured one, within the range that was stated.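

In this assay, nitro in place of amino on an aromatic carbon, para to a large group, gives a number 5 percentage points higher from compound 2 to compound 4 (within the scatter). Set beside the earlier step, the change shows no difference between the two cores: the same change on two cores in this assay, a number 5 percentage points higher (within the scatter) from compound 3 to compound 1 and a number 5 percentage points higher (within the scatter) from compound 2 to compound 4, 0 percentage points apart, within the scatter of two such steps. For the compounds shown here, this shows only that the change stays within the scatter on both cores at the one concentration tested; it does not show that the step would carry over to a core starting from a clearly higher number.

The compounds shown leave open whether a carboxylic acid, a nitrile or a methoxy group on the aromatic ring would move the number in this assay beyond the scatter. The same holds for a longer chain in place of the methyl on the shared core.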